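The compounds below may be only part of what the source reports. "The series", "measured", "known", "first", "only" and "open" are said of these compounds alone.

Working notes on the series. Two compounds have so far been examined for how much of them cultured cells tolerate. Compound 1 `O=S(=O)(Nc1ccc(-c2nc3ccccc3o2)cc1)c1ccc(F)c(C(F)(F)F)c1` was run in an ADME assay on HEK293 cells (Homo sapiens) for cytotoxicity, read by resazurin assay, with a stated time of 48 h (a lower number here means that less compound is tolerated, a higher number that more compound is tolerated), and compound 1 gives 82000 nM. Compound 2 `O=S(=O)(Nc1ccc2oc(-c3ccccc3)nc2c1)c1ccccc1C(F)(F)F`, built on the shared core with the sulfonamide and the substituents arranged differently, gives 80000 nM in this assay. On the numbers available compound 1 stands at the top, but its gap to compound 2 lies within the scatter, so the two readings cannot be told apart and no ordering is drawn from them. Both sit in a region where a good deal of compound is tolerated.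

Compound 3 `O=S(=O)(Nc1ccc(-c2nc3ccccc3o2)cc1)c1ccc(F)cc1` remains to be measured in this assay. It differs from compound 1 in one place: hydrogen in place of trifluoromethyl on an aromatic carbon. For the measured compounds named here, no measured pair differs in a single place, so there is no precedent for the size of this step; compound 2 differs from compound 1 in more than one place and gives no guidance. Given that compound 1 gives 82000 nM and compound 2 gives 80000 nM in this assay, no step beyond the scatter is expected in either direction. The step of a 1.1-fold higher number from compound 1 to compound 3 (0.04 log units; within the scatter) is expected to be small. Compound 3 is estimated at 90000 nM, with a range from 40000 nM to 200000 nM.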

Compound 3, half-maximal cytotoxic concentration: > 100000 nM
Compound 3 was reported as a limit; the forecaster's own chance of this, stated with the estimate: 30%; at least 1.1-fold (0.04 log units) between middle value and limit.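

In this assay compound 3 gives > 100000 nM, which is a limit of the assay and not a number. Hydrogen in place of trifluoromethyl on this aromatic carbon, ortho to a fluoro group, gives an at least 1.2-fold higher number from compound 1 to compound 3 (0.08 log units; that floor lies within the scatter); this is the first step in the series that changes one place only, and it shows that losing the trifluoromethyl group does not bring a lower number here. Only a floor for the step can be read, and it cannot be said whether the change moves the number beyond the scatter, because the reading for compound 3 stops at the limit of the assay: the limit of > 100000 nM in this assay, at which 1 of the 3 values shown sits.

The compounds shown leave open what other groups on this aromatic carbon, such as an amine, a carboxylic acid or a longer alkyl chain, would give in this assay. Also open, from the compounds shown here alone, is whether hydrogen in place of trifluoromethyl would give a comparable result on compound 2, where the sulfonamide and the substituents are arranged differently on the shared core.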